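The source may hold more compounds than are shown below. What is called first, only, known or untested is meant among the compounds shown, and "the series" means these compounds.

Three compounds have been measured in a physicochemical assay for lipophilicity; a higher number here means a more lipophilic compound, a lower number a more polar compound:
compound 1 `CCc1ccccc1-c1nc(N)nc(N)n1`, 1.65
compound 2 `Cc1c(N(C)C)c(=O)n(C)c(=O)n1-c1ccc(Cl)cc1`, 2.32
compound 3 `C=CCN(CC=C)c1c(C)n(-c2ccccc2)c(=O)n(C)c1=O`, 2.59

Of the three, compound 1 gives the lowest number. Compound 2 stands higher, beyond the scatter, and compound 3 stands higher still, also beyond the scatter. Compound 4 `CCOc1ccccc1-c1nc(N)nc(N)n1` has not yet been measured in this assay. It differs from compound 1 in one place: ethoxy in place of ethyl on an aromatic carbon. For the measured compounds named here, no pair of measured compounds shows this change, so the size of its effect cannot be read from the data and has to be estimated. The change is expected to lower the number moderately, by a number 0.45 log units lower from compound 1 to compound 4 (beyond the scatter). Compound 4 is therefore estimated at 1.2, within a range from 0.8 to 1.6.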

Compound 4, partition coefficient: 1.03
For compound 4 the middle estimate is 0.17 log units above the measured one; low and high end bracket the measured number.
By their numbers in this assay, from the lowest: compound 4; then compound 1; then compounds 2 and 3 (each within the scatter of the next).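

Ethoxy in place of ethyl on this aromatic carbon gives, in this assay, a number 0.62 log units lower from compound 1 to compound 4 (beyond the scatter), the first step in the set between compounds that differ in one place. The number at this position therefore shifts beyond the scatter when one oxygen enters and the count of two carbons stays the same. Nothing at hand gives a reason for this step. The compounds shown leave open how methoxy, propoxy or an amine on this aromatic carbon would compare. They also leave open whether the same change on another aromatic carbon gives a step of similar size.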